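This account rests on a few compounds, and the source may have more. Where it says the series, first, only, none or still open, it means among the compounds named here.

Measured so far in an ADME assay on HepG2 2.2.15 cells (Homo sapiens) for cytotoxicity; on this read-out lower numbers stand for stronger inhibition and higher numbers for weaker inhibition:
compound 1, `O=C1CCCC2=C1C(c1ccc(F)cc1Cl)N=C(c1ccccn1)N2`: 620000 nM
compound 2, `O=C1CCCC2=C1C(c1ccc(F)cc1Cl)N=C(c1ncccc1F)N2`: 1370000 nM
compound 3, `CC1(C)CC(=O)C2=C(C1)NC(c1cnccn1)=NC2c1ccc(F)cc1Cl`: 773000 nM

Compound 1 and compound 2 share a core; from compound 2 to compound 1 the change is hydrogen in place of fluoro on an aromatic carbon, and this assay shows a 2.2-fold lower number from compound 2 to compound 1 (0.34 log units; beyond the scatter). Compound 3 rests on a different core, and its difference from compound 2 is not broken down here. Its value lies within the scatter of both compound 1 and compound 2.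

Compound 4, `CC1(C)CC(=O)C2=C(C1)NC(c1cnccn1)=NC2c1ccccc1Cl`, is not yet measured. It differs from compound 3 by hydrogen in place of fluoro on an aromatic carbon, the same kind of change as from compound 2 to compound 1, but here on a ring of carbon only, meta to a chloro group and para to a large group, rather than on a ring with one nitrogen, ortho to a large group. Because a 2.2-fold lower number from compound 2 to compound 1 (0.34 log units; beyond the scatter) was only modest and the surroundings differ, the step from compound 3 to compound 4 is expected to be small, a 1.2-fold lower number from compound 3 to compound 4 (0.08 log units; within the scatter). Compound 4 is thus estimated at 650000 nM, between 300000 nM and 1400000 nM.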

Compound 4, half-maximal inhibitory concentration: 623000 nM
Beside the measured number, compound 4's estimate is 1.0-fold (0.02 log units) above it; the range from low to high includes it.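

In this assay, hydrogen in place of fluoro on an aromatic carbon, here the change from 2-chloro-4-fluorophenyl to 2-chlorophenyl, gives a 1.2-fold lower number from compound 3 to compound 4 (0.09 log units; within the scatter). Set beside the earlier case on another core, the two steps do not differ beyond the scatter: the same change on two cores in this assay, a 2.2-fold lower number (0.34 log units; beyond the scatter) from compound 2 to compound 1 and a 1.2-fold lower number (0.09 log units; within the scatter) from compound 3 to compound 4, 1.8-fold (0.25 log units) apart, within the scatter of two such steps This is consistent with the change carrying from one core to the other, but with only two pairs, one of them within the scatter, it does not establish a shared size for the step or show that it would hold on further cores.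

The compounds shown leave open how other groups would behave in this assay. On these data alone, an amine, a carboxylic acid or a longer chain in place of the fluoro remains untested here.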